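The source may hold more compounds than are shown below. What is called first, only, known or untested is meant among the compounds shown, and "the series" means these compounds.

Of the compounds shown here, two have been measured so far. Compound 1 `Cc1nc(S(C)(=O)=O)ccc1Oc1ncnc(OC2CCN(C(=O)O[C@@H](C)CF)CC2)c1F` carries a carbamate on the ring nitrogen; in a functional assay on isolated protein for inhibition of Glucose-dependent insulinotropic receptor (Rattus norvegicus), read by HTRF and cAMP accumulation (a lower number here means that less compound is needed, a higher number that more compound is needed for the effect), compound 1 gives 1680 nM. Among the compounds with values here, compound 2 `Cc1nc(S(C)(=O)=O)ccc1Oc1ncnc(OC2CCN(C(=O)c3noc(C(C)C)n3)CC2)c1F` instead carries an aromatic heterocycle on that carbonyl carbon; in this assay compound 2 gives 176 nM, which is the lowest of the two numbers known. Within the data shown here, the only step seen so far, a 9.5-fold lower number from compound 1 to compound 2 (0.98 log units; beyond the scatter), shows that exchanging the carbamate for a ring-bearing amide helped clearly.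

Compound 3 `Cc1nc(S(C)(=O)=O)ccc1Oc1ncnc(OC2CCN(C(=O)c3ncc(Cl)cn3)CC2)c1F` keeps everything of compound 2 except the ring on the carbonyl carbon: 5-chloropyrimidin-2-yl in place of 5-isopropyl-1,2,4-oxadiazol-3-yl on a carbonyl carbon. Among the measured compounds shown here, no measured step compares two different rings at this position, so the step from compound 1 to compound 2 bears on it only loosely; it says that an aromatic ring on the carbonyl is tolerated, not which ring is better. With one ring swapped for another, the expected change for compound 3 in this assay is small, a 1.1-fold higher number from compound 2 to compound 3 (0.06 log units; within the scatter), within the scatter in either direction. The estimate for compound 3 in this assay is therefore 200 nM, with a range from 60 nM to 650 nM.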

Compound 3, half-maximal effective concentration: 30.9 nM
Compound 3: the middle estimate sits 6.5-fold (0.81 log units) above what was measured, and the stated range ends above it.
By their numbers in this assay, from the lowest: compound 3; then compound 2; then compound 1.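

Within the data shown here, this is the first comparison of two different rings on the carbonyl carbon, and it shows that the choice of ring matters and not only the presence of one: in this assay, 5-chloropyrimidin-2-yl in place of 5-isopropyl-1,2,4-oxadiazol-3-yl gives a 5.7-fold lower number from compound 2 to compound 3 (0.76 log units; beyond the scatter) at this position. Set against the carbamate, the same ring gives a 54-fold lower number from compound 1 to compound 3 (1.74 log units; beyond the scatter), a large step where the earlier ring change gave only a modest one, so the amide-type attachment on the ring nitrogen has more to offer than compound 2 alone revealed. Nothing measured here explains why one ring gives a lower number than the other.

Compound 2 and compound 3 differ in the ring and in the group on it at once, so these compounds cannot say whether the chlorine, the six-membered ring or the loss of the isopropyl group accounts for the step. A plain pyrimidin-2-yl, a 5-methylpyrimidin-2-yl and a 5-chloropyridin-2-yl on the same carbonyl carbon would help to separate these parts, and a 5-isopropylpyrimidin-2-yl would test the isopropyl group on the new ring.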